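Phenylethenyl in Place of a Fluorophenyl-Alkyne on a Shared Core

The source may report more compounds than this note shows. Statements on the series, on what has been measured and on what is new or still open speak of the compounds shown alone.

Measured compounds:
compound 1 `CCCCC#Cc1cc([C@@H]2O[C@H](CO)[C@@H](O)[C@H]2O)n2ncnc(N)c12`: 1000 nM
compound 2 `Nc1ncnn2c([C@@H]3O[C@H](CO)[C@@H](O)[C@H]3O)cc(C#Cc3ccc(F)cc3)c12`: 55400 nM
compound 3 `Nc1ncnn2c([C@@H]3O[C@H](CO)[C@@H](O)[C@H]3O)cc(-c3ccc(F)cc3)c12`: 65600 nM

In a functional assay on CAPAN-1 cells (Homo sapiens) for antiproliferative activity, with a stated time of 72 h (on this read-out higher numbers stand for weaker inhibition and lower numbers for stronger inhibition), compound 2 gives 55400 nM, the second highest of the three numbers. Compound 3 gives 65600 nM, and the step of a 1.2-fold higher number from compound 2 to compound 3 (0.07 log units; within the scatter) lies within the scatter. Compound 1 gives 1000 nM, and a 55-fold higher number from compound 1 to compound 2 (1.74 log units; beyond the scatter) is a large loss. Compound 4 `Nc1ncnn2c([C@@H]3O[C@H](CO)[C@@H](O)[C@H]3O)cc(/C=C/c3ccccc3)c12` differs from compound 2 by 2-phenylethenyl in place of 2-(4-fluorophenyl)ethynyl on an aromatic carbon. Both measured steps bear on this: the 4-fluorophenyl compounds, whether joined through a triple bond or directly, sit close together, and only the butyl-bearing compound 1 inhibits strongly. Since compound 4 still carries an aromatic ring at this place, a step of a 1.4-fold lower number from compound 2 to compound 4 (0.14 log units; within the scatter) is expected, within the scatter. Compound 4 is therefore estimated at 40000 nM, with a range from 10000 nM to 150000 nM.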

Compound 4, half-maximal inhibitory concentration: 2600 nM
Estimate against measurement, compound 4: 15-fold (1.19 log units) above; the whole stated range lies above it.
By their numbers in this assay, from the lowest: compound 1; then compound 4; then compounds 2 and 3 (each within the scatter of the next).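

A six-membered aromatic ring at this place is compatible with fairly strong inhibition: 2-phenylethenyl gives a large gain over the 2-(4-fluorophenyl)ethynyl group (a 21-fold lower number from compound 2 to compound 4 (1.33 log units; beyond the scatter)) and over the directly attached 4-fluorophenyl group (a 25-fold lower number from compound 3 to compound 4 (1.40 log units; beyond the scatter)). Compound 4 also comes within a modest step of the hex-1-yn-1-yl compound (a 2.6-fold higher number from compound 1 to compound 4 (0.41 log units; beyond the scatter)). Nothing measured here explains these differences.

From the compounds shown here alone, compound 4 differs from compound 2 in both the link and the fluorine, so which of these matters remains open. Going by these compounds, whether an amine or a carboxylic acid on the phenyl ring would preserve this inhibition also remains open.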